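A few compounds are considered here, and "the series" means these few. Any claim that something is new, unique, unknown or untested is made for them only; others in the source may bear on it.

Three measured members of the series share one core. Compound 1 `O=C(NO)c1cnc(N2CCN(S(=O)(=O)c3ccc4ccccc4c3)CC2)s1` carries the naphthalene sulfonyl; in a functional assay on MCF7 cells (Homo sapiens) for antiproliferative activity (on this read-out higher numbers stand for weaker inhibition of growth and lower numbers for stronger inhibition of growth), compound 1 gives 2000 nM. Compound 2 `Cc1ccc(S(=O)(=O)N2CCN(c3ncc(C(=O)NO)s3)CC2)cc1` carries the 4-methylphenyl sulfonyl, and in this assay compound 2 gives 350 nM. Compound 3 `COc1ccc(S(=O)(=O)N2CCN(c3ncc(C(=O)NO)s3)CC2)cc1OC` carries the dimethoxyphenyl sulfonyl; in this assay compound 3 gives 2000 nM.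

Compound 2 holds the lowest of the three numbers and is the most potent of the set: its gaps to compound 1 and to compound 3 are each well beyond the scatter of repeat measurements.

Compound 4 `O=C(NO)c1cnc(N2CCN(S(=O)(=O)c3ccccc3)CC2)s1` is not yet measured. It differs from compound 2 in one place: hydrogen in place of methyl on an aromatic carbon, or, read one bond further out, 4-methylphenyl to phenyl.

Going by the values given here, no measured pair shows this exact change, so the size of the step from compound 2 to compound 4 must be guessed from the spread of the three numbers. The two other substitution patterns both sit at the weaker end, so a loss on removing the methyl is expected, of moderate size and beyond the scatter. The expected step is a 2.6-fold higher number from compound 2 to compound 4 (0.41 log units; beyond the scatter). Compound 4 is estimated at 900 nM, within a range of 300 nM to 2500 nM.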

Compound 4, concentration for 50% growth inhibition: 10000 nM
Compound 4: the middle estimate sits 11-fold (1.05 log units) below what was measured; the measured number lies above the stated range.
By their numbers in this assay, from the lowest: compound 2; then compounds 1 and 3 (each within the scatter of the next); then compound 4.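

Replacing methyl with hydrogen on the aromatic carbon para to a large group gives a 29-fold higher number from compound 2 to compound 4 (1.46 log units; beyond the scatter) in this assay, so this position is far from indifferent to the change. Going by these compounds alone, this is the only single-place step so far, and it involves just one carbon leaving, with no ring, no hydrogen-bond donor or acceptor and no net charge in the departing group. No measurement at hand bears on why so small a change has so large a result.

From the compounds shown here alone, only methyl and hydrogen can be compared at this position, so it remains open whether the higher potency of the 4-methylphenyl compound is specific to methyl or would also be seen with ethyl, a chlorine atom or a single methoxy group in the same place. Going by these compounds, it is also open whether moving the methyl to another carbon of the six-membered ring would keep that potency, and whether a step of this size would recur on a different read-out.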